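Swapping methyl for nitro in a small compound series

This account rests on a few compounds, and the source may have more. Where it says the series, first, only, none or still open, it means among the compounds named here.

Compound 1 `Cc1ccc(Cn2c(N)nc3cc(Cl)c(Cl)cc32)cc1` gives 40000 nM
Compound 2 `Nc1nc2cc(Cl)c(Cl)cc2n1Cc1ccccc1Cl` gives 36000 nM
Compound 3 `Nc1nc2cc(Cl)c(Cl)cc2n1Cc1cc(C(F)(F)F)cc(C(F)(F)F)c1` gives 17000 nM

In a functional assay on CEM-SS cells (Homo sapiens) for cytotoxicity (a higher number here means a weaker inhibitor, a lower number a stronger inhibitor), compound 1 (40000 nM) sits level with compound 2 (36000 nM) within the scatter, while compound 3 (17000 nM) shows a lower number, beyond the scatter. Compound 1 thus stands at the high end of this small set. Compound 4 `Nc1nc2cc(Cl)c(Cl)cc2n1Cc1ccc([N+](=O)[O-])cc1` carries nitro in place of methyl on an aromatic carbon, para to a large group. For the measured compounds named here, no measured pair differs in one place only, so no direct step guides the forecast. All three measured values lie close together, so no step beyond the scatter is expected in this assay. The estimate means a 1.3-fold lower number from compound 1 to compound 4 (0.12 log units; within the scatter) and nothing larger is expected. For compound 4 the estimated value is 30000 nM with an expected range from 12000 nM to 80000 nM as the likely span.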

Compound 4, half-maximal inhibitory concentration: 32000 nM
The estimate for compound 4 lay 1.1-fold (0.03 log units) below the measured number; low and high end bracket the measured number.
By their numbers in this assay, from the lowest: compounds 3, 4, 2 and 1 (each within the scatter of the next, the first and the last beyond it).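

Nitro in place of methyl on an aromatic carbon, para to a large group, gives the first direct step in this assay: a 1.3-fold lower number from compound 1 to compound 4 (0.10 log units; within the scatter). This step lies within the scatter, so the two groups cannot be told apart here, although nitro brings hydrogen-bond acceptors and methyl brings none. No supporting measurement bears on this result.

From the compounds shown here alone, whether an amine or a carboxylic acid at this same position would also stand level with methyl and nitro remains open.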